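Aryl groups on the five-membered ring: half-life notes

The source may hold more compounds than are shown below. What is called first, only, known or untested is meant among the compounds shown, and "the series" means these compounds.

Measured so far:
compound 1 `N#Cc1ccc(F)cc1Cn1c(N2CCC[C@@H](N)C2)nc2c(-c3cccs3)c[nH]c2c1=O`: 0.585 h
compound 2 `N#Cc1ccc(F)cc1Cn1c(N2CCC[C@@H](N)C2)nc2cc[nH]c2c1=O`: 3.33 h
compound 3 `N#Cc1ccc(F)cc1Cn1c(N2CCC[C@@H](N)C2)nc2c(-c3ccsc3)c[nH]c2c1=O`: 2.67 h

In an ADME assay on microsomes from liver (Homo sapiens) for metabolic stability, read by LC-MS, tested at 1 mM (on this read-out lower numbers stand for a shorter-lived compound and higher numbers for a longer-lived compound), compound 2 gives 3.33 h, the highest of the three numbers; compound 3 lies within the scatter of it, while compound 1 lies beyond the scatter below it. Compound 4 `CS(=O)(=O)c1ccccc1-c1c[nH]c2c(=O)n(Cc3cc(F)ccc3C#N)c(N3CCC[C@@H](N)C3)nc12` differs from compound 2 by 2-(methylsulfonyl)phenyl in place of hydrogen on an aromatic carbon. Among the compounds with values here, two measured steps bear on this. Adding thiophen-3-yl on the same carbon gave a 1.2-fold lower number from compound 2 to compound 3 (0.10 log units; within the scatter), nothing beyond the scatter. Removing thiophen-2-yl gave a 5.7-fold higher number from compound 1 to compound 2 (0.76 log units; beyond the scatter), so the presence of that aryl group went with a modestly lower number. An aryl group at this carbon has thus either left the half-life unchanged or lowered it modestly; the entering 2-(methylsulfonyl)phenyl is a further aryl group, and no case with a substituted phenyl here has been measured. Compound 4 is therefore expected to show a 2.1-fold lower number from compound 2 to compound 4 (0.32 log units; beyond the scatter), a modest lowering, with a wide range. For compound 4 the estimate is 1.6 h, between 0.6 h and 4 h.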

Compound 4, half-life: > 3.33 h
Compound 4: no number, only a limit (the forecaster's own chance of this, stated with the estimate: 5%); middle value at least 2.0-fold (0.31 log units) away from the limit.
By their numbers in this assay, from the lowest: compound 1; then compounds 3 and 2 (each within the scatter of the next).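

In this assay compound 4 gives > 3.33 h, which is a limit and not a number. The steps read as a number no lower from compound 2 to compound 4 (the limit leaves the size open), an at least 1.2-fold higher number from compound 3 to compound 4 (0.09 log units; that floor lies within the scatter) and an at least 5.6-fold higher number from compound 1 to compound 4 (0.75 log units; beyond the scatter), so only the last of these floors clears the scatter. Within the data shown here, this is the first substituted phenyl on this aromatic carbon, and it shows that an aryl group carrying a sizeable substituent need not shorten the half-life here: of the three aryl groups, only thiophen-2-yl in compound 1 lies beyond the scatter below compound 2, while compounds 3 and 4 do not.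

Going by these compounds, how far compound 4 lies beyond its limit stays open. Also open, on these data alone, is whether plain phenyl, or a phenyl bearing an amine or a carboxylic acid in place of methylsulfonyl, would behave the same way.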